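The source may report more compounds than this note shows. Statements on the series, on what has been measured and on what is new or still open speak of the compounds shown alone.

Compound 1 `CCC(=O)NCCC(=O)c1cc(OC)ccc1N`: 0.24%
Compound 2 `CCCC(=O)NCCC(=O)c1cc(OC)ccc1N`: 7.35%
Compound 3 `CCNC(=O)NCCC(O)c1ccccc1N`: 18.3%

In an assay for inhibition of Nitric oxide synthase, inducible (Homo sapiens), read by scintillation counting, with a stated time of 30 min, tested at 1 mM (on this read-out lower numbers stand for less inhibition and higher numbers for more inhibition at the one concentration tested (going by the name of the read-out)), compound 1 gives 0.24% and compound 2 gives 7.35%. The change between them is methyl in place of hydrogen on a saturated chain carbon, two bonds along the chain from a carbonyl carbon, and the resulting step of a number 7.1 percentage points higher from compound 1 to compound 2 (within the scatter) lies within the scatter. Compound 3 gives 18.3% in this assay, the highest of the three numbers, and its distance to each of the other two is beyond the scatter. The difference between the core of compound 3 and the core of compound 1 is not broken down here.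

Compound 4 `CCCNC(=O)NCCC(O)c1ccccc1N` has not yet been measured in this assay. It differs from compound 3 by methyl in place of hydrogen on a saturated chain carbon, two bonds along the chain from an amide-type nitrogen. This is the same kind of change as that from compound 1 to compound 2, though the place differs: there the carbon sat two bonds along the chain from a carbonyl carbon, here it sits two bonds along the chain from an amide-type nitrogen. Because a number 7.1 percentage points higher from compound 1 to compound 2 (within the scatter) stayed within the scatter, the step of a number 3.7 percentage points higher from compound 3 to compound 4 (within the scatter) is expected to be small as well. Compound 4 is estimated to give 22% in this assay, between 8% and 38%.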

Compound 4, a percentage reported as inhibition, at one concentration (the size of the read-out at that concentration, not a potency): 19%
Beside the measured number, compound 4's estimate is 3 percentage points above it; low and high end bracket the measured number.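

In this assay, ethylamino to propylamino, with methyl in place of hydrogen on a saturated chain carbon, gives a number 0.7 percentage points higher from compound 3 to compound 4 (within the scatter). Set beside the earlier step on the other core, the change gives no sign of reading differently from one core to the other: the same change on two cores in this assay, a number 7.1 percentage points higher (within the scatter) from compound 1 to compound 2 and a number 0.7 percentage points higher (within the scatter) from compound 3 to compound 4, 6.4 percentage points apart, within the scatter of two such steps. Among the compounds shown here, this shows only that the change left the number within the scatter on both cores; it does not show that the change has any real effect on either core, and two pairs, with the change at different places, do not establish a rule for the series.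

The compounds shown leave open whether a butyl chain, an isopropyl group or a phenyl ring in place of the propyl group of compound 4 would give a step beyond the scatter. They also leave open whether an amine or a carboxylic acid at the end of that chain would do so.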